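Cytotoxicity notes: morpholine amide replacing the tert-butyl ketone

The source may hold more compounds than are shown below. What is called first, only, known or untested is meant among the compounds shown, and "the series" means these compounds.

Measured so far in an ADME assay on Huh-7 cells (Homo sapiens) for cytotoxicity, with a stated time of 72 h; on this read-out higher numbers stand for lower toxicity in this test and lower numbers for higher toxicity in this test:
compound 1, `CC(C)[C@H]1C(O)=C(C2=NS(=O)(=O)c3c(OCCC(N)=O)cccc32)C(=O)N1Cc1ccccc1`, gives > 33000 nM, which is a limit of this assay.
compound 2, `CC(C)[C@H]1C(O)=C(C2=NS(=O)(=O)c3c(OCC(=O)C(C)(C)C)cccc32)C(=O)N1Cc1ccccc1`, gives > 33000 nM, which is likewise a limit of this assay.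

Compound 2 therefore stands at the limit of this assay, where (the limit of > 33000 nM in this assay, at which 2 of the 2 values shown sit). For the measured compounds named here, the one measured step, a step that the two limits leave unreadable from compound 1 to compound 2, cannot be read for size or direction because of the limit of > 33000 nM in this assay, at which 2 of the 2 values shown sit; both ends of it are limits.

Compound 3, `CC(C)[C@H]1C(O)=C(C2=NS(=O)(=O)c3c(OCC(=O)N4CCOCC4)cccc32)C(=O)N1Cc1ccccc1`, differs from compound 2 by morpholin-4-yl in place of tert-butyl on a carbonyl carbon. The measured step sits on the same side chain but gives no readable size, so nothing beyond the scatter can be drawn from it in either direction. The working expectation is that compound 3 also returns a limit in this assay. Compound 3 is thus estimated at 50000 nM, with a range of 20000 nM to 200000 nM, which means an expected step that the limit leaves unreadable from compound 2 to compound 3, within the scatter.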

Compound 3, half-maximal cytotoxic concentration: > 33000 nM
Compound 3: no number, only a limit (the forecaster's own chance of this, stated with the estimate: 85%); the middle value does not contradict the limit.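

In this assay compound 3 gives > 33000 nM, which is a limit. No step from compound 1 or compound 2 to compound 3 can be read: the limit of > 33000 nM in this assay, at which 3 of the 3 values shown sit.

The compounds shown leave open whether these side-chain changes alter the cytotoxic concentration at all in this assay.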